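A few compounds are considered here, and "the series" means these few. Any claim that something is new, unique, unknown or untested is made for them only; others in the source may bear on it.

Measured compounds in a functional assay on MCF7 cells (Homo sapiens) for antiproliferative activity; on this read-out lower numbers stand for stronger inhibition and higher numbers for weaker inhibition:

- compound 1, `COc1cc(Cc2nc3c(N)nc(F)nc3n2CC2CCCO2)cc(OC)c1OC`: 22900 nM
- compound 2, `COc1cc(Cc2nc3c(N)ncnc3n2CC2CC2)cc(OC)c1OC`: 75900 nM
- compound 3, `CCCn1c(Cc2cc(OC)c(OC)c(OC)c2)nc2c(N)ncnc21`: 46800 nM

Compound 1 stands at the low end of these three numbers; both other compounds give higher numbers in this assay, and in each case the gap is beyond the scatter, so compound 1 is the most potent of the set as measured.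

Compound 4, `CCCCn1c(Cc2cc(OC)c(OC)c(OC)c2)nc2c(N)nc(F)nc21`, has not been measured. It differs from compound 1 in one place: propyl in place of oxolan-2-yl on a saturated chain carbon bound to an aromatic nitrogen. Within the data shown here, the only measured step that touches this kind of change is the one from compound 2 to compound 3, which also swaps one saturated group on the carbon bound to the aromatic nitrogen for another: a 1.6-fold lower number from compound 2 to compound 3 (0.21 log units; within the scatter). Among the measured compounds shown here, compound 1 and compound 3 differ in two places at once, so their values show only that a fluorine-bearing core with an oxolanylmethyl chain sits somewhat lower than a fluorine-free core with a propyl chain.

On this basis the alkyl exchange is expected to move this assay little, if at all; compound 4 is estimated at 28000 nM, within 10000 nM to 75000 nM, a step of a 1.2-fold higher number from compound 1 to compound 4 (0.09 log units; within the scatter) that is expected to stay within the scatter.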

Compound 4, half-maximal inhibitory concentration: 24000 nM
For compound 4 the middle estimate is 1.2-fold (0.07 log units) above the measured one; the range from low to high includes it.
By their numbers in this assay, from the lowest: compounds 1, 4, 3 and 2 (each within the scatter of the next, the first and the last beyond it).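

In this assay, the exchange of propyl for oxolan-2-yl on a saturated chain carbon bound to an aromatic nitrogen gives a 1.0-fold higher number from compound 1 to compound 4 (0.02 log units; within the scatter), so (oxolan-2-yl)methyl and butyl cannot be told apart at this position on the fluorine-bearing core of compound 1, and the ring with its hydrogen-bond acceptor leaves no trace in the number. The earlier step, a 1.6-fold lower number from compound 2 to compound 3 (0.21 log units; within the scatter), covered only an exchange of cyclopropyl for ethyl on a fluorine-free core, whereas this pair extends the same flat reading to a ring carrying a hetero atom, and neither step among the compounds shown goes against it. No measured evidence bears on why this position tolerates the exchange, so the flat reading stands as an observation only.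

The compounds shown span only neutral saturated groups here, which leaves open whether the flat reading would hold for a chain carrying an amine or a carboxylic acid, or for a longer chain such as octyl. Among these compounds, no pair among them differs only in the fluorine on the core, so what that atom contributes on its own remains unread.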